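Swapping Trifluoromethyl for Tert-Butyl in an Inactive Pair

A few compounds are considered here, and "the series" means these few. Any claim that something is new, unique, unknown or untested is made for them only; others in the source may bear on it.

Two measured compounds share one core and differ only in the group on the outer ring. Compound 1 `CC(C)n1ncc2c(C(=O)NCc3cn(-c4ccccc4)nn3)cccc21` and compound 2 `CC(C)n1ncc2c(C(=O)NCc3cn(Cc4ccc(C(F)(F)F)cc4)nn3)cccc21` have both been tested. In a functional assay on MCF7 cells (Homo sapiens) for inhibition, read by MTT assay, with a stated time of 72 h (on this read-out lower numbers stand for stronger inhibition and higher numbers for weaker inhibition), compound 1 gives > 40000 nM, which is a limit of the assay and not a number. In this assay compound 2 gives > 40000 nM, again a limit rather than a measured number. Compound 2 thus stands at the limit, like every value shown (the limit of > 40000 nM in this assay, at which 2 of the 2 values shown sit), so no order between the two can be read. Compound 3 `CC(C)n1ncc2c(C(=O)NCc3cn(Cc4ccc(C(C)(C)C)cc4)nn3)cccc21` is not yet measured; it differs from compound 2 by tert-butyl in place of trifluoromethyl on an aromatic carbon. No measured step is shown, so nothing points in either direction. The expected step from compound 2 to compound 3 is a step that the limit leaves unreadable from compound 2 to compound 3, none beyond the scatter. Compound 3 is therefore estimated at 50000 nM, within 15000 nM to 200000 nM in this assay, most likely again reported only as a limit.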

Compound 3, half-maximal inhibitory concentration: > 40000 nM
Compound 3: a limit, no number; the forecaster's own chance of this, stated with the estimate: 80%; the middle value does not contradict the limit.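

For the compounds shown here, compound 2 and compound 3 each give only a limit, not a number, so no step between them can be read. The compounds shown leave open whether any group on the outer ring can produce a measurable inhibition of these cells: the limit of > 40000 nM in this assay, at which 3 of the 3 values shown sit.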